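The compounds below may be only part of what the source reports. "The series", "measured", "known", "first", "only" and "open" are said of these compounds alone.

Measured compounds:
- compound 1, `COc1cc2c(Oc3ccc(NC(=O)c4nn(-c5ccccc5)c(=O)cc4C)cc3F)ccnc2cc1OCCCN1CCCC1`: 460 nM in a functional assay on NCI-H460 cells (Homo sapiens) for inhibition, read by MTT assay, with a stated time of 72 h; a higher number here means a weaker inhibitor, a lower number a stronger inhibitor
- compound 2, `COc1cc2c(Oc3ccc(NC(=O)c4nn(-c5ccccc5C(F)(F)F)c(=O)cc4C)cc3F)ccnc2cc1OCCCN1CCCC1`: 210 nM in this assay
- compound 3, `COc1ccc(-n2nc(C(=O)Nc3ccc(Oc4ccnc5cc(OCCCN6CCCC6)c(OC)cc45)c(F)c3)c(C)cc2=O)cc1`: 3610 nM in this assay

Compound 3 stands at the highest number of the three in this assay. Its nearest neighbour is compound 1, reached by a 7.8-fold higher number from compound 1 to compound 3 (0.89 log units; beyond the scatter); the furthest is compound 2, reached by a 17-fold higher number from compound 2 to compound 3 (1.24 log units; beyond the scatter). Compound 4, `COc1cc2c(Oc3ccc(NC(=O)c4nn(-c5ccc(F)c(F)c5)c(=O)cc4C)cc3F)ccnc2cc1OCCCN1CCCC1`, differs from compound 3 by one change: 3,4-difluorophenyl in place of 4-methoxyphenyl on an aromatic nitrogen.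

Going by the values given here, two measured steps bear on this. First, a 7.8-fold higher number from compound 1 to compound 3 (0.89 log units; beyond the scatter) shows that the methoxy group on the ring attached to the aromatic nitrogen goes with a markedly higher number, so its removal in compound 4 should undo most of that. Second, a 2.2-fold lower number from compound 1 to compound 2 (0.34 log units; beyond the scatter) shows that a fluorine-bearing group on that ring went with a modest move towards a lower number. Among the compounds with values here, no measured compound carries a 3,4-difluorophenyl at this position, so the exact landing point is uncertain. Taken together, compound 4 is expected to land near compound 1 and perhaps somewhat lower, a step of a 10-fold lower number from compound 3 to compound 4 (1.01 log units; beyond the scatter) in this assay. The estimate for compound 4 in this assay is 350 nM, with a range from 150 nM to 900 nM.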

Compound 4, half-maximal inhibitory concentration: 170 nM
Beside the measured number, compound 4's estimate is 2.1-fold (0.31 log units) above it, within the range that was stated.
By their numbers in this assay, from the lowest: compounds 4 and 2 (each within the scatter of the next); then compound 1; then compound 3.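

In this assay, the change from 4-methoxyphenyl to 3,4-difluorophenyl on the aromatic nitrogen gives the largest step seen at this position (a 21-fold lower number from compound 3 to compound 4 (1.33 log units; beyond the scatter)), and it does more than restore the unsubstituted phenyl ring, since a 2.7-fold lower number from compound 1 to compound 4 (0.43 log units; beyond the scatter) shows that a second fluorine-bearing ring also goes with a lower number than phenyl. The two fluorine-bearing rings, 3,4-difluorophenyl and 2-(trifluoromethyl)phenyl, cannot be told apart in this assay (a 1.2-fold lower number from compound 2 to compound 4 (0.09 log units; within the scatter)), so among these four compounds substituents at different places on this ring reach the same level, while the 4-methoxyphenyl of compound 3 stands apart on the high side. Nothing given here accounts for these differences.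

The compounds shown leave open whether both fluorines of compound 4 are needed, as a single fluorine at either place, or a chlorine or a nitrile in their stead, would test. They also leave open how this ring would respond to an amine or a carboxylic acid, and whether a methoxy elsewhere on the ring carries the same penalty as in compound 3.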